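Lengthening an Alkyl Chain on a Fluorinated Core

The compounds below may be only part of what the source reports. "The series", "measured", "known", "first", "only" and "open" are said of these compounds alone.

Compound 1, `Cc1nc2nc(-c3ccccc3)cc(C(F)(F)F)c2c(=O)n1Cc1cn(CCC(F)(F)C(F)(F)C(F)(F)C(F)(F)C(F)(F)C(F)(F)F)nn1`. In a functional assay on THP-1 cells (Homo sapiens) for cytotoxicity, read by MTT assay, with a stated time of 24 h (on this read-out lower numbers stand for stronger inhibition and higher numbers for weaker inhibition), compound 1 gives > 200 ug/mL, which is a limit of the assay rather than a number.
Compound 2, `CCc1nc2nc(-c3ccccc3)cc(C(F)(F)F)c2c(=O)n1Cc1cn(CCC(F)(F)C(F)(F)C(F)(F)C(F)(F)C(F)(F)C(F)(F)F)nn1`. In this assay compound 2 gives > 200 ug/mL, again a limit of the assay.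

Compound 2 therefore stands only at a limit, and its true value is not resolved. Among the compounds with values here, the one measured step, a step that the two limits leave unreadable from compound 1 to compound 2, cannot be sized due to the limit of > 200 ug/mL in this assay, at which 2 of the 2 values shown sit. Compound 3, `CCCCCCc1nc2nc(-c3ccccc3)cc(C(F)(F)F)c2c(=O)n1Cc1cn(CCC(F)(F)C(F)(F)C(F)(F)C(F)(F)C(F)(F)C(F)(F)F)nn1`, differs from compound 2 by butyl in place of hydrogen on a saturated chain carbon, two bonds along the chain from an aromatic carbon. Within the data shown here, no measured step bears on such a lengthening with a readable size, and the single comparison available, a step that the two limits leave unreadable from compound 1 to compound 2, gives neither direction nor magnitude. The expectation for compound 3 is that it stays near the same limit, with the step of a number no higher from compound 2 to compound 3 (the limit leaves the size open) expected to be small. The estimate for compound 3 in this assay is 200 ug/mL, within a range from 60 ug/mL to 400 ug/mL.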

Compound 3, half-maximal inhibitory concentration: > 200 ug/mL
Compound 3 gave a limit, no number (the forecaster's own chance of this, stated with the estimate: 60%); the middle value sits exactly at the limit.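

The steps among compound 1, compound 2 and compound 3 cannot be read in this assay, due to one shared limit of the assay: the limit of > 200 ug/mL in this assay, at which 3 of the 3 values shown sit.

Going by these compounds, whether going from methyl to ethyl to hexyl on the shared core changes cytotoxicity at all, and in which direction, stays open.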